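Swapping Fluoro for Chloro in a Small Antiproliferative Series

The compounds below may be only part of what the source reports. "The series", "measured", "known", "first", "only" and "open" are said of these compounds alone.

Four close relatives are compared in a functional assay on B16-F10 cells (Mus musculus) for antiproliferative activity, read by ELISA and MTT assay, with a stated time of 48 h; a higher number here means a weaker inhibitor, a lower number a stronger inhibitor. Compound 1 `O=C(/C=C/c1ccccc1)NS(=O)(=O)c1ccc(F)cc1` gives 2.1 ug/mL. Compound 2 `O=C(/C=C/c1ccccc1)NS(=O)(=O)c1ccc(Cl)cc1` differs from compound 1 by chloro in place of fluoro on an aromatic carbon, and in this assay compound 2 gives 2.2 ug/mL, so the step is a 1.0-fold higher number from compound 1 to compound 2 (0.02 log units; within the scatter). Compound 3 `O=C(/C=C/c1ccc(Cl)cc1)NS(=O)(=O)c1ccc(F)cc1` has a core that differs from the core of compound 1 by chloro in place of hydrogen on an aromatic carbon, and in this assay compound 3 gives 2 ug/mL, a step of a 1.1-fold lower number from compound 1 to compound 3 (0.02 log units; within the scatter). All three numbers sit within the usual scatter of one another, so no order among them can be read.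

Compound 4 `O=C(/C=C/c1ccc(Cl)cc1)NS(=O)(=O)c1ccc(Cl)cc1` has not yet been measured. It differs from compound 3 by chloro in place of fluoro on an aromatic carbon, the same change that separates compound 2 from compound 1, made at a place described in identical words. Because that change between compound 1 and compound 2 gave only a 1.0-fold higher number from compound 1 to compound 2 (0.02 log units; within the scatter), the expected step is a 1.1-fold higher number from compound 3 to compound 4 (0.02 log units; within the scatter). Compound 4 is therefore estimated at 2.1 ug/mL, with a likely range from 1.2 ug/mL to 3.6 ug/mL.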

Compound 4, half-maximal inhibitory concentration: 2.5 ug/mL
Compound 4: middle estimate off by 1.2-fold (0.08 log units), on the low side, within the range that was stated.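

On the core of compound 3, chloro in place of fluoro gives a 1.3-fold higher number from compound 3 to compound 4 (0.10 log units; within the scatter) in this assay, and this step agrees with the same change on the core of compound 1: the same change on two cores in this assay, a 1.0-fold higher number (0.02 log units; within the scatter) from compound 1 to compound 2 and a 1.3-fold higher number (0.10 log units; within the scatter) from compound 3 to compound 4, 1.2-fold (0.08 log units) apart, within the scatter of two such steps. Chloro in place of hydrogen gives a 1.1-fold higher number from compound 2 to compound 4 (0.06 log units; within the scatter), and this step likewise agrees with its earlier counterpart: the same change on two cores in this assay, a 1.1-fold lower number (0.02 log units; within the scatter) from compound 1 to compound 3 and a 1.1-fold higher number (0.06 log units; within the scatter) from compound 2 to compound 4, 1.2-fold (0.08 log units) apart, within the scatter of two such steps. So each change carries from one core to the other in the limited sense that it stays within the scatter on both, but this does not show that the two steps are truly equal, that either change is without any effect, or that the agreement would hold on a third core.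

The compounds shown carry only hydrogen, fluoro and chloro at these places, so it remains open whether a larger or different group, such as bromo, methoxy, an amine or a carboxylic acid, would move the number beyond the scatter. On these data alone, it also remains open whether these small steps would look the same on cells other than the ones used here.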